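Fused core series: phenyl to chloromethyl, growth inhibition

This account rests on a few compounds, and the source may have more. Where it says the series, first, only, none or still open, it means among the compounds named here.

Measured so far:
compound 1 `Nc1nn2c(O)cc(-c3cc([N+](=O)[O-])c(Cl)cc3Cl)nc2c1[N+](=O)[O-]` — > 50 ug/mL
compound 2 `Nc1nn2c(O)cc(-c3ccccc3)nc2c1[N+](=O)[O-]` — > 50 ug/mL
compound 3 `Nc1nn2c(O)cc(-c3ccc(F)cc3)nc2c1[N+](=O)[O-]` — > 50 ug/mL

All three measured compounds share the same core and differ only in the group on the aromatic carbon next to the ring nitrogen. In a functional assay on K562 cells (Homo sapiens) for inhibition (on this read-out lower numbers stand for stronger inhibition of growth and higher numbers for weaker inhibition of growth), compound 1 gives only a limit, > 50 ug/mL, and no number. In this assay compound 2 likewise gives only a limit, > 50 ug/mL. Compound 3 also stops at a limit, > 50 ug/mL. Accordingly a step that the two limits leave unreadable from compound 2 to compound 3 cannot be read as a step of any size, and the only evidence on the series is the limit of > 50 ug/mL in this assay, at which 3 of the 3 values shown sit.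

Compound 4 `Nc1nn2c(O)cc(CCl)nc2c1[N+](=O)[O-]` has not yet been measured. Relative to compound 2 the change is chloromethyl in place of phenyl on an aromatic carbon: the phenyl leaves and a chloromethyl enters at the same place. Among the measured compounds shown here, no measured step speaks to this change; the one pair that differs in a single place is unreadable. For the measured compounds named here, nothing in the numbers so far shows that any group at this position has brought a compound beneath the limit, and none of the three measured compounds goes against that.

On that basis compound 4 is expected to give about 50 ug/mL, with a range from 20 ug/mL to 150 ug/mL. The step that this estimate means, a number no higher from compound 2 to compound 4 (the limit leaves the size open), is expected to stay within the scatter, and the most probable outcome is that compound 4 also reports only a limit.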

Compound 4, concentration for 50% growth inhibition: > 50 ug/mL
Compound 4: no number, only a limit; the forecaster's own chance of this, stated with the estimate: 75%; the middle value sits exactly at the limit.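

In this assay compound 4 also gives only a limit, > 50 ug/mL. No new step can be read from this result: the steps to compound 4 from compound 2 and from compound 3 remain unreadable. The compounds shown leave open whether any group at this place on the shared core yields a measurable growth inhibition value.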